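Extending the Fluoroethoxy Chain on an Oxime Ether

The compounds below may be only part of what the source reports. "The series", "measured", "known", "first", "only" and "open" are said of these compounds alone.

Measured so far:
compound 1 `Fc1cccc(O/N=C2/C=C(C#Cc3ccccn3)CCC2)n1`: 9.15 nM
compound 2 `FCCOCO/N=C1/C=C(C#Cc2ccccn2)CCC1`: 8.41 nM

Of the compounds shown here, two sharing the same core have been tested in an assay on brain (strain Sprague-Dawley) for displacement of a labelled ligand from metabotropic glutamate receptor 5 (Rattus norvegicus), with a stated time of 45 min; a lower number here means a stronger inhibitor, a higher number a weaker inhibitor. In this assay compound 1 gives 9.15 nM, and compound 2 gives 8.41 nM. For the measured compounds named here, the only measured step is a 1.1-fold lower number from compound 1 to compound 2 (0.04 log units; within the scatter), so the two numbers cannot be told apart; compound 2 shows the lower of the two, but its distance to compound 1 is within the scatter, and no order between them can be claimed.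

Compound 3 `FCCOCCO/N=C1/C=C(C#Cc2ccccn2)CCC1` has not been measured. Its difference from compound 2 is (2-fluoroethoxy)methyl in place of 2-fluoroethoxy on a saturated chain carbon bound to an oxygen on an unsaturated carbon. Going by the values given here, no measured step bears directly on this change: the one step available, a 1.1-fold lower number from compound 1 to compound 2 (0.04 log units; within the scatter), swaps a different group at a different place and itself stays within the scatter. With no step shown that moves the number, the account expects compound 3 to differ from compound 2 by no more than a 1.1-fold higher number from compound 2 to compound 3 (0.05 log units; within the scatter), in no particular direction. For compound 3 the estimate in this assay is therefore 9.5 nM, with a range from 4 nM to 22 nM.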

Compound 3, inhibition constant: 3.8 nM
For compound 3 the middle estimate is 2.5-fold (0.40 log units) above the measured one, outside the stated range (below it).
By their numbers in this assay, from the lowest: compound 3; then compounds 2 and 1 (each within the scatter of the next).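

In this assay, for the compounds shown here, the chain on the oxime oxygen is the first place where a change moves the number: a 2.2-fold lower number from compound 2 to compound 3 (0.35 log units; beyond the scatter) when (2-fluoroethoxy)methyl stands in place of 2-fluoroethoxy on a saturated chain carbon bound to an oxygen on an unsaturated carbon. The earlier swap, by contrast, gave a 1.1-fold lower number from compound 1 to compound 2 (0.04 log units; within the scatter) and so showed no sensitivity to the group at the oxygen, while the present change is small and still registers, though the effect is modest. Compound 3 also stands apart from the fluoropyridine ether, with a 2.4-fold lower number from compound 1 to compound 3 (0.38 log units; beyond the scatter), which gives it the lowest number of the three, and nothing available here explains this gain.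

Going by these compounds, a single lengthening step sets no trend, so it remains open whether a still longer chain, such as 3-(2-fluoroethoxy)propyl, would lower the number further or raise it again. Also open, on these data alone, is what the fluorine of the chain contributes, and whether a hydroxyl or an amine in its place would keep the number.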